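This account rests on a few compounds, and the source may have more. Where it says the series, first, only, none or still open, it means among the compounds named here.

The measured compounds and their values in an assay on HL-60 cells for agonist activity at vitamin D3 receptor (Homo sapiens), read by microscopy, with a stated time of 96 h; a higher number here means that more compound is needed for the effect, a lower number that less compound is needed:
Compound 1 `CC[C@@H](C)[C@H](NC(=O)c1ccc(C(CC)(CC)c2ccc(OCC(=O)C(C)(C)C)c(C)c2)n1CC)C(=O)OC`: compound 1 gives 590 nM.
Compound 2 `CCn1c(C(=O)NCCCN(C)C)ccc1C(CC)(CC)c1ccc(OCC(=O)C(C)(C)C)c(C)c1`: compound 2 gives 96 nM.
Compound 3 `C#CCNC(=O)c1ccc(C(CC)(CC)c2ccc(OCC(=O)C(C)(C)C)c(C)c2)n1CC`: compound 3 gives 2200 nM.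

Compound 3 stands at the highest number of the three. Its nearest neighbour is compound 1, with a 3.7-fold higher number from compound 1 to compound 3 (0.57 log units; beyond the scatter); its furthest is compound 2, with a 23-fold higher number from compound 2 to compound 3 (1.36 log units; beyond the scatter). Compound 4 `CCn1c(C(=O)NCC(OC)OC)ccc1C(CC)(CC)c1ccc(OCC(=O)C(C)(C)C)c(C)c1` differs from compound 3 only on the amide side chain: dimethoxymethyl in place of ethynyl on a saturated chain carbon bound to an amide-type nitrogen.

Among the compounds with values here, the step that bears most directly on this change is the one from compound 2 to compound 3, where a basic amine-bearing chain was exchanged for ethynyl and the number rose by a 23-fold higher number from compound 2 to compound 3 (1.36 log units; beyond the scatter). The step from compound 1 to compound 3 points the same way, a 3.7-fold higher number from compound 1 to compound 3 (0.57 log units; beyond the scatter), so the ethynyl end appears to sit at the weak end of this series. Replacing it with dimethoxymethyl, a larger group carrying two acceptors but no basic nitrogen, is therefore expected to bring the number down somewhat in this assay, though less than the amine of compound 2 did. The estimate for compound 4 is 800 nM, within 300 nM to 2500 nM, an expected step of a 2.8-fold lower number from compound 3 to compound 4 (0.44 log units; beyond the scatter).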

Compound 4, half-maximal effective concentration: 130 nM
Estimate against measurement, compound 4: 6.2-fold (0.79 log units) above; the whole stated range lies above it.
By their numbers in this assay, from the lowest: compounds 2 and 4 (each within the scatter of the next); then compound 1; then compound 3.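

In this assay a dimethylamino end on the amide side chain proves unnecessary for a low number: dimethoxymethyl in its place gives a 1.4-fold higher number from compound 2 to compound 4 (0.13 log units; within the scatter) and the two side chains cannot be told apart. The same dimethoxymethyl end gives a 17-fold lower number from compound 3 to compound 4 (1.23 log units; beyond the scatter) and the full side chain gives a 4.5-fold lower number from compound 1 to compound 4 (0.66 log units; beyond the scatter) so the high number of the propargyl amide belongs to that side chain and not to every amide lacking the amine. Nothing measured here explains these differences.

The compounds shown leave open whether a single methoxy group at the chain end would match dimethoxymethyl or whether both oxygens are needed. They also leave open whether a plain propyl chain would behave like propargyl or like 2,2-dimethoxyethyl, which would separate the effect of the triple bond from that of chain length.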